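The source may report more compounds than this note shows. Statements on the series, on what has been measured and on what is new or still open speak of the compounds shown alone.

In an assay on lung for displacement of a labelled ligand from cysteinyl leukotriene receptor 1 (Cavia porcellus) (a higher number here means weaker binding, a lower number tighter binding), compound 2 `O=C(O)c1cc(Cl)cc2c(=O)cc(-c3cccc(/C=C/c4ccc5ccccc5n4)c3)oc12` gives 11 nM, the lowest of the two numbers, and compound 1 `O=C(O)c1cc(Br)cc2c(=O)cc(-c3cccc(/C=C/c4ccc5ccccc5n4)c3)oc12` gives 17 nM, a difference that stays within the scatter. Within the data shown here, the only measured step, a 1.5-fold lower number from compound 1 to compound 2 (0.19 log units; within the scatter), swapped one halogen for another on the same aromatic carbon. Compound 3 `Cc1cc(C(=O)O)c2oc(-c3cccc(/C=C/c4ccc5ccccc5n4)c3)cc(=O)c2c1` carries the change (methyl in place of chloro on an aromatic carbon). Since the halogen swap moved the dissociation constant little, a comparable exchange at this position is expected to produce no step beyond the scatter, and compound 3 is estimated at 13 nM in this assay, within 5 nM to 35 nM, a step of a 1.2-fold higher number from compound 2 to compound 3 (0.07 log units; within the scatter).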

Compound 3, dissociation constant: 13 nM
The estimate for compound 3 equals the measured number at the digits printed, and the stated range covers the measured number.
By their numbers in this assay, from the lowest: compounds 2, 3 and 1 (each within the scatter of the next).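

In this assay, methyl in place of chloro gives a 1.2-fold higher number from compound 2 to compound 3 (0.07 log units; within the scatter) and methyl in place of bromo gives a 1.3-fold lower number from compound 1 to compound 3 (0.12 log units; within the scatter) at this position, meta to a carboxy group. The position therefore accepts a carbon group as well as either halogen with no step beyond the scatter, which the halogen swap alone could not show. No evidence here accounts for this flat result. The compounds shown leave open whether an amine, a methoxy group or a longer chain on this aromatic carbon would keep the number within the scatter. They also leave open how plain hydrogen at this position would compare.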